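Fluoro in place of hydrogen on compound 1

The compounds below may be only part of what the source reports. "The series", "measured", "known", "first", "only" and "open" are said of these compounds alone.

- compound 1 `COC(=O)NC12CCC(n3cc(-c4ccc(Cl)c(N)c4)c4c(N)ncnc43)(CC1)CC2` gives 1.1 L/kg
- compound 2 `COC(=O)N[C@H]1CC[C@@H](n2cc(-c3ccc(Cl)c(N)c3)c3c(N)ncnc32)CC1` gives 0.37 L/kg

In an ADME assay on the whole organism (Mus musculus, strain BALB/c) for pharmacokinetics, read by LC-MS, at a dose of 2 mg/kg by the intravenous route (on this read-out lower numbers stand for narrower distribution and higher numbers for wider distribution into tissues), compound 1 stands highest of the two measured compounds, and the gap to compound 2 lies beyond the scatter. Compound 3 `COC(=O)NC12CCC(n3cc(-c4cc(N)c(Cl)cc4F)c4c(N)ncnc43)(CC1)CC2` is not yet measured. It differs from compound 1 by fluoro in place of hydrogen on an aromatic carbon in one place: fluoro in place of hydrogen on an aromatic carbon. Within the data shown here, no measured pair shows this change, so no direction can be argued from the data, and in this assay no shift beyond the scatter is expected. The expected size of no change at the digits printed from compound 1 to compound 3 (within the scatter) stays within that scatter. The estimate for compound 3 is 1.1 L/kg (range 0.6 L/kg to 2 L/kg).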

Compound 3, volume of distribution at steady state: 2.4 L/kg
For compound 3 the middle estimate is 2.2-fold (0.34 log units) below the measured one, and the stated range ends below it.
By their numbers in this assay, from the lowest: compound 2; then compound 1; then compound 3.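

In this assay, fluoro in place of hydrogen on the aromatic carbon ortho to a large group and para to an amino group gives a 2.2-fold higher number from compound 1 to compound 3 (0.34 log units; beyond the scatter). Among these compounds, this is the first one-place step, and it shows that this position responds to a single fluorine atom, with the number moving upward.
Nothing at hand gives a cause for this step.
Still open, as far as these compounds go, is whether a methoxy group or a nitrile on this carbon would move the number the same way. Also open, from the compounds shown here alone, is whether fluoro here would do the same on compound 2.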